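The source may report more compounds than this note shows. Statements on the series, on what has been measured and on what is new or still open speak of the compounds shown alone.

Measured compounds:
- Compound 1, `Cc1ncc2c(N)c(C#N)c(N)nc2n1`: 783000 nM
- Compound 2, `Cc1nc(C(C)(C)C)nc2nc(N)c(C#N)c(N)c12`: 37000 nM

Of the compounds shown here, two have been measured in a physicochemical assay for solubility, in phosphate buffer, with a stated time of 18 h; on this read-out lower numbers stand for lower solubility and higher numbers for higher solubility. Compound 1 gives 783000 nM in this assay. Compound 2 gives 37000 nM in this assay, the lowest of the two numbers; the nearest point is compound 1, and the gap between them is beyond the scatter of this assay. The two compounds differ in more than one place, so the gap cannot be tied to a single structural change.

Compound 3, `CC(C)(C)c1nc(-c2ccccn2)c2c(N)c(C#N)c(N)nc2n1`, has not yet been measured in this assay. It is derived from compound 2 by a single change: pyridin-2-yl in place of methyl on an aromatic carbon. Going by the values given here, nothing among the measured compounds records the effect of exactly this change, so any view of it rests on general experience alone. A move of compound 2 toward compound 3 in this assay is expected to lower the number by a moderate step, a 3.1-fold lower number from compound 2 to compound 3 (0.49 log units; beyond the scatter), beyond the scatter but not by a wide margin. Compound 3 is therefore estimated to reach 12000 nM in this assay, most likely falling between 3000 nM and 50000 nM.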

Compound 3, solubility: 87000 nM
For compound 3 the middle estimate is 7.3-fold (0.86 log units) below the measured one, and the stated range ends below it.
By their numbers in this assay, from the lowest: compound 2; then compound 3; then compound 1.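

In this assay, putting pyridin-2-yl in place of methyl on an aromatic carbon next to the ring nitrogen gives a 2.4-fold higher number from compound 2 to compound 3 (0.37 log units; beyond the scatter) and so counts as a modest step, though one beyond the scatter. Going by these compounds alone, this is the first step that can be tied to a single structural change, and it gives this position its first direct reading: in this one pair, a larger group bringing a six-membered aromatic ring goes with a higher number, not a lower one. No measurement shown here accounts for the direction or size of this step.

As far as these compounds go, what remains open is whether the ring nitrogen of pyridin-2-yl matters, which a plain phenyl ring at the same carbon would test, and whether a small amine or a longer alkyl chain there would move the number in the same direction. From the compounds shown here alone, it is also open whether the same swap would give a similar step on a core without the tert-butyl group, since a single pair cannot show how far this result carries.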